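A few compounds are considered here, and "the series" means these few. Any claim that something is new, unique, unknown or untested is made for them only; others in the source may bear on it.

Working notes on the series. In a functional assay on G-361 cells (Homo sapiens) for cytotoxicity, read by MTT assay, with a stated time of 3 days (on this read-out lower numbers stand for stronger inhibition and higher numbers for weaker inhibition), compound 1 `N#Cc1c(-c2ccccc2)nc(SCc2nc3ccccc3[nH]2)nc1N1CCNCC1` gives 2.5 nM, compound 2 `CN1CCN(c2nc(SCc3nc4ccccc4[nH]3)nc(-c3ccccc3)c2C#N)CC1` gives 14.7 nM and compound 3 `Cc1ccc(S(=O)(=O)N2CCN(c3nc(SCc4nc5ccccc5[nH]4)nc(-c4ccccc4)c3C#N)CC2)cc1` gives 4.38 nM. Compound 3 thus lies within the scatter of compound 1, while compound 2 carries the highest number of the three.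

Compound 4 `N#Cc1c(-c2ccccc2)nc(SCc2nc3ccccc3[nH]2)nc1N1CCN(S(=O)(=O)c2ccccc2[N+](=O)[O-])CC1` differs from compound 3 at one place: 2-nitrophenyl in place of 4-methylphenyl on a sulfonyl sulfur. In words, this is 2-nitrophenyl in place of 4-methylphenyl on a sulfonyl sulfur.

For the measured compounds named here, no measured step changes the group on the sulfonyl sulfur, so the data hold no direct precedent for this swap. The nearest evidence comes from changes on the amine nitrogen in a ring. The step of a 1.8-fold higher number from compound 1 to compound 3 (0.24 log units; within the scatter) stays within the scatter, whereas a 5.9-fold higher number from compound 1 to compound 2 (0.77 log units; beyond the scatter) and a 3.4-fold lower number from compound 2 to compound 3 (0.53 log units; beyond the scatter) are modest. Even the replacement of a whole sulfonyl substituent by hydrogen therefore moved the number little, and a change further out on that substituent is expected to do no more than that. No step beyond the scatter is expected, and no direction can be called with confidence.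

In this assay the estimated step is a 1.4-fold higher number from compound 3 to compound 4 (0.14 log units; within the scatter). Compound 4 is expected at about 6 nM, with an estimated range from 2 nM to 20 nM.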

Compound 4, half-maximal inhibitory concentration: 9.6 nM
Beside the measured number, compound 4's estimate is 1.6-fold (0.20 log units) below it; measured number inside the range.
By their numbers in this assay, from the lowest: compounds 1 and 3 (each within the scatter of the next); then compounds 4 and 2 (each within the scatter of the next).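

In this assay, for the compounds shown here, the group on the sulfonyl sulfur is not silent: a 2.2-fold higher number from compound 3 to compound 4 (0.34 log units; beyond the scatter) is the first step at this place, and it lies beyond the scatter, though only modestly. Hydrogen and (4-methylphenyl)sulfonyl on the amine nitrogen in a ring stayed within the scatter of each other, whereas a 3.8-fold higher number from compound 1 to compound 4 (0.58 log units; beyond the scatter) lies beyond it, so the effect of a sulfonyl substituent there depends on the aryl group it carries; a 1.5-fold lower number from compound 2 to compound 4 (0.19 log units; within the scatter) also stays within the scatter, so (2-nitrophenyl)sulfonyl and methyl on that nitrogen cannot be told apart, while (4-methylphenyl)sulfonyl and methyl can. Nothing at hand accounts for this step.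

The swap changes both the substituent on the aryl ring and where it sits, so the compounds shown cannot separate the nitro group from the loss of the methyl group or from its placement. Plain phenyl, 4-nitrophenyl and 2-aminophenyl on the sulfonyl sulfur would divide these readings, and it remains open whether any group there can reach or pass the number of compound 1 at 2.5 nM.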